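Swapping the aryl on an acrylamide tail: expected potency

The source may report more compounds than this note shows. Statements on the series, on what has been measured and on what is new or still open speak of the compounds shown alone.

Measured so far:
- compound 1, `Clc1cccc(Nc2ncnc3ccc(NCc4cccnc4)cc23)c1`: 2670 nM
- compound 2, `O=C(/C=C/c1cccnc1)Nc1ccc2ncnc(Nc3cccc(Cl)c3)c2c1`: 4320 nM

Both compounds share the same core and were tested in a functional assay on A549 cells (Homo sapiens) for antiproliferative activity, read by MTT assay, with a stated time of 48 h; a higher number here means a weaker inhibitor, a lower number a stronger inhibitor. Compound 1 gives 2670 nM and compound 2 gives 4320 nM. Compound 2 has the higher of the two numbers, but its gap to compound 1 is within the scatter, so the two cannot be told apart on these values.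

Compound 3, `O=C(/C=C/c1ccc(Br)s1)Nc1ccc2ncnc(Nc3cccc(Cl)c3)c2c1`, has not yet been measured. It differs from compound 2 only in the group at the end of the unsaturated chain: 5-bromothiophen-2-yl in place of pyridin-3-yl on a double-bonded chain carbon bound to a double-bonded chain carbon. Within the data shown here, no measured pair shows what such an exchange does here, so there is nothing to build a directional expectation on, and the step from compound 2 to compound 3 is expected to be small, a 1.1-fold lower number from compound 2 to compound 3 (0.03 log units; within the scatter), not beyond the scatter in either direction. Compound 3 is therefore estimated at 4000 nM in this assay, with a range from 1500 nM to 12000 nM.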

Compound 3, half-maximal inhibitory concentration: 1580 nM
Estimate against measurement, compound 3: 2.5-fold (0.40 log units) above; low and high end bracket the measured number.
By their numbers in this assay, from the lowest: compounds 3, 1 and 2 (each within the scatter of the next, the first and the last beyond it).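

The group at the end of the acrylamide tail does affect the result: in this assay, 5-bromothiophen-2-yl in place of pyridin-3-yl on a double-bonded chain carbon bound to a double-bonded chain carbon gives a 2.7-fold lower number from compound 2 to compound 3 (0.44 log units; beyond the scatter) and is a modest step, but one beyond the scatter. The two groups have the same counts of heavy atoms, hydrogen-bond donors and acceptors, so those counts do not separate them; they differ in ring size and in their atoms, with sulfur and bromine entering and nitrogen leaving. Nothing shown here explains why the number falls.

The exchange alters the ring and adds bromine at once, so a plain thiophen-2-yl or a 5-chlorothiophen-2-yl at this place would be needed to tell which of the two matters. Also open, on these data alone, is how an amine or a carboxylic acid on this ring would behave.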